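Isopropylsulfonyl in place of pentyl: notes on compound 4

The source may hold more compounds than are shown below. What is called first, only, known or untested is meant among the compounds shown, and "the series" means these compounds.

Three compounds of the series carry numbers in a functional assay (aorta) with Oryctolagus cuniculus as the target; on this read-out lower numbers stand for stronger inhibition and higher numbers for weaker inhibition. Compound 1 `OCc1ccc(-c2nn(Cc3c(F)cccc3F)c3ccccc23)o1` gives 15000 nM. Compound 2 `OCc1ccc(-c2nn(Cc3ccccc3F)c3ncccc23)o1` gives 1700 nM; 1700 nM (2 entries). Compound 3 `CCCCCc1cnc(-c2nn(Cc3ccccc3F)c3ncccc23)nc1N` gives 200000 nM, the highest of the two single numbers, with compound 1 the nearest and that gap beyond the scatter. Compound 4 `CC(C)S(=O)(=O)c1cnc(-c2nn(Cc3ccccc3F)c3ncccc23)nc1N` differs from compound 3 by isopropylsulfonyl in place of pentyl on an aromatic carbon. Going by the values given here, no measured pair in this set shows this change, so its direction has no backing in the data; the step from compound 3 to compound 4 is expected to stay within the scatter, a 1.7-fold lower number from compound 3 to compound 4 (0.22 log units; within the scatter). On that basis compound 4 is expected near 120000 nM, in a range from 15000 nM to 600000 nM.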

Compound 4, half-maximal inhibitory concentration: 517000 nM
For compound 4 the middle estimate is 4.3-fold (0.63 log units) below the measured one; the measured number falls inside the stated range.
By their numbers in this assay, from the lowest: compound 1; then compound 3; then compound 4.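

Going by these compounds alone, on the aromatic carbon ortho to an amino group, isopropylsulfonyl in place of pentyl gives in this assay a 2.6-fold higher number from compound 3 to compound 4 (0.41 log units; beyond the scatter) as the only measured step at this position. Exchanging the alkyl chain for the sulfonyl group therefore moves the number up, not down, although modestly. Nothing shown accounts for this step.

On these data alone, what a hydrogen, a shorter chain such as ethyl or a carboxylic acid would give at this carbon remains open. The direction of the change rests on this single pair, and whether it holds on other compounds of the series is also unknown.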